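Ethoxycarbonyl in Place of Acetyl: Compound 4 Awaits Measurement

The source may report more compounds than this note shows. Statements on the series, on what has been measured and on what is new or still open speak of the compounds shown alone.

Of the compounds shown here, three sharing one core have been tested in a functional assay on HepG2 cells (Homo sapiens) for cytotoxicity, read by sulforhodamine B assay, with a stated time of 72 h; a lower number here means a stronger inhibitor, a higher number a weaker inhibitor. Compound 1 `Cc1c(-c2csc(/N=c3\sc(-c4ccccc4)nn3-c3ccccc3)n2)c(=O)n(-c2ccccc2)n1C` gives > 100000 nM, which is a limit of the assay and not a number. Compound 2 `CC(=O)c1nn(-c2ccccc2)/c(=N/c2nc(-c3c(C)n(C)n(-c4ccccc4)c3=O)cs2)s1` gives 67100 nM in this assay. Compound 3 `CC(=O)c1nn(-c2ccc(Cl)cc2)/c(=N/c2nc(-c3c(C)n(C)n(-c4ccccc4)c3=O)cs2)s1` gives > 100000 nM, again a limit rather than a number. Going by the values given here, compound 2 therefore holds the only number among the three, the other two values being limits, as the limit of > 100000 nM in this assay, at which 2 of the 3 values shown sit, records. The step of an at least 1.4-fold lower number from compound 1 to compound 2 (0.17 log units; that floor lies within the scatter) puts acetyl in place of phenyl on an aromatic carbon, and the step of an at least 1.4-fold higher number from compound 2 to compound 3 (0.17 log units; that floor lies within the scatter) puts chloro in place of hydrogen on an aromatic carbon. Compound 4 `CCOC(=O)c1nn(-c2ccccc2)/c(=N/c2nc(-c3c(C)n(C)n(-c4ccccc4)c3=O)cs2)s1` differs from compound 2 by ethoxy in place of methyl on a carbonyl carbon. Both measured steps, an at least 1.4-fold lower number from compound 1 to compound 2 (0.17 log units; that floor lies within the scatter) and an at least 1.4-fold higher number from compound 2 to compound 3 (0.17 log units; that floor lies within the scatter), rest on a floor within the scatter, and neither touches the carbonyl carbon. Compound 4 is therefore expected to show no step beyond the scatter, a 1.0-fold lower number from compound 2 to compound 4 (0.00 log units; within the scatter). The estimated value for compound 4 in this assay is 67000 nM, within 30000 nM to 150000 nM.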

Compound 4, half-maximal inhibitory concentration: > 100000 nM
Compound 4 gave a limit, no number (the forecaster's own chance of this, stated with the estimate: 40%); at least 1.4-fold (0.17 log units) between middle value and limit.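

Ethoxy in place of methyl on a carbonyl carbon gives an at least 1.4-fold higher number from compound 2 to compound 4 (0.17 log units; that floor lies within the scatter), the first change shown at this position in this assay, and its floor does not set ethoxycarbonyl apart from acetyl. Compound 4 adds one more value that is a limit and not a number: the limit of > 100000 nM in this assay, at which 3 of the 4 values shown sit. The step that links the ethoxycarbonyl compound to the phenyl compound cannot be read, as both of its values are limits.

Whether any group on this carbonyl carbon can move the value beyond the scatter remains open, as a carboxylic acid, an amide or a longer chain such as a butyl ester is not among the compounds shown. Going by these compounds, with compound 2 alone holding a number, the true size of the change from acetyl to ethoxycarbonyl also remains unknown.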